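Substitution at the pendant phenyl ring of pyrazolopyridinone cores

A few compounds are considered here, and "the series" means these few. Any claim that something is new, unique, unknown or untested is made for them only; others in the source may bear on it.

Compound 1, `Cc1cc2nn(-c3ccccc3)c(N)c2c(=O)[nH]1`, gives -11% in an assay on isolated protein for inhibition of ribosomal protein S6 kinase alpha-1 (Homo sapiens), read by mobility shift assay, tested at 30 uM; on this read-out lower numbers stand for less inhibition and higher numbers for more inhibition at the one concentration tested (going by the name of the read-out).
Compound 2, `Nc1c2c(=O)[nH]c(-c3ccccc3)cc2nn1-c1ccccc1`, gives 38% in this assay.
Compound 3, `COc1ccc(-c2cc3nn(-c4ccccc4)c(N)c3c(=O)[nH]2)cc1`, gives 4% in this assay.

Compound 3 stands second highest of the three numbers in this assay: compound 1 lies a number 15 percentage points higher from compound 1 to compound 3 (beyond the scatter), while compound 2 lies a number 34 percentage points lower from compound 2 to compound 3 (beyond the scatter). The unmeasured compound 4, `CN1CCN(c2ccc(-c3cc4nn(-c5ccccc5)c(N)c4c(=O)[nH]3)cc2)CC1`, differs from compound 3 in one place: 4-methylpiperazin-1-yl in place of methoxy on an aromatic carbon. Among the compounds with values here, the only measured step at this place is the one in which methoxy entered in place of hydrogen, a number 34 percentage points lower from compound 2 to compound 3 (beyond the scatter), a large drop; the other two steps, a number 49 percentage points higher from compound 1 to compound 2 (beyond the scatter) and a number 15 percentage points higher from compound 1 to compound 3 (beyond the scatter), concern the methyl site and bear only indirectly. Within the data shown here, no measured step shows what a 4-methylpiperazin-1-yl group does here, so the expected step, a number 1 percentage points higher from compound 3 to compound 4 (within the scatter), is none beyond the scatter. Compound 4 is therefore expected to give about 5%, within a range from -15% to 30%.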

Compound 4, a percentage reported as inhibition, at one concentration (the size of the read-out at that concentration, not a potency): 19%
For compound 4 the middle estimate is 14 percentage points below the measured one, within the range that was stated.
By their numbers in this assay, from the lowest: compound 1; then compound 3; then compound 4; then compound 2.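

In this assay, the change on the aromatic carbon proved not to be a fixed penalty for any group placed there: with 4-methylpiperazin-1-yl in place of methoxy there is a number 15 percentage points higher from compound 3 to compound 4 (beyond the scatter). Against the unsubstituted phenyl ring, however, the larger group still costs inhibition, with a number 19 percentage points lower from compound 2 to compound 4 (beyond the scatter), so both substituted compounds lie under compound 2 and the size of the loss depends on which group enters. Nothing given here explains this difference between the two groups.

The compounds shown leave open whether a morpholine ring, a dimethylamino group or a carboxylic acid at this place would match the hydrogen of compound 2 or also lower the number. They also leave open whether a fluorine or a chlorine, much smaller than either group, would lower it at all.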